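Two Stereocentres Inverted at Once in a Hydroxylated Piperidine Acid

The compounds below may be only part of what the source reports. "The series", "measured", "known", "first", "only" and "open" are said of these compounds alone.

Compound 3 `O=C(O)[C@H]1NC[C@H](O)[C@@H](O)[C@H]1O` gives 31% in an assay for inhibition of alpha-N-acetylgalactosaminidase (Gallus gallus), tested at 1000 uM (a higher number here means more inhibition at the concentration tested (going by the name of the read-out), a lower number less inhibition), the largest of the three numbers shown, though its gap to compound 1 lies within the scatter. Compound 1 `O=C(O)[C@H]1NC[C@H](O)[C@H](O)[C@H]1O` gives 21% in this assay, and compound 2 `O=C(O)[C@H]1NCC=C[C@H]1O` gives 0.2%. Going by the values given here, the only measured step that bears on a change of configuration alone is a number 10 percentage points higher from compound 1 to compound 3 (within the scatter), resting on (the fact that compounds 1 and 3 differ only in the configuration as drawn), and it stays within the scatter. Compound 4 `O=C(O)[C@H]1NC[C@@H](O)[C@H](O)[C@H]1O` differs from compound 3 as follows: the two compounds have the same atoms and bonds and differ only in configuration as drawn: 2 of 4 stereo elements differ; a stereocentre at a saturated ring carbon is drawn S in compound 3 and R in compound 4; a stereocentre at a saturated ring carbon is drawn R in compound 3 and S in compound 4. One inversion left the number essentially unchanged, but two inversions at once reach beyond anything measured, so no direction can be inferred. Compound 4 is expected to give 20%, between 0% and 50%. The expected step is a number 11 percentage points lower from compound 3 to compound 4 (beyond the scatter), within the scatter.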

Compound 4, a percentage reported as inhibition, at one concentration (the size of the read-out at that concentration, not a potency): 4.2%
Compound 4: middle estimate off by 15.8 percentage points, on the high side, within the range that was stated.
By their numbers in this assay, from the lowest: compounds 2 and 4 (each within the scatter of the next); then compounds 1 and 3 (each within the scatter of the next).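

Configuration alone can now move the number in this assay beyond the scatter, which the earlier single inversion, a number 10 percentage points higher from compound 1 to compound 3 (within the scatter), did not do. Inverting a different stereocentre at a saturated ring carbon gives a number 16.8 percentage points lower from compound 1 to compound 4 (beyond the scatter), and inverting two at once gives a number 26.8 percentage points lower from compound 3 to compound 4 (beyond the scatter), so the stereocentres do not all count alike. The drop from the single inversion rests on stereochemistry alone: the fact that compounds 1 and 4 differ only in the configuration as drawn.

Why this stereocentre counts remains open. So does how a fluorine or an amine in place of its hydroxyl would read in this assay.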